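A few compounds are considered here, and "the series" means these few. Any claim that something is new, unique, unknown or untested is made for them only; others in the source may bear on it.

In a functional assay on HL-60 cells (Homo sapiens) for inhibition, read by CCK-8 assay, with a stated time of 48 h, tested at 20 uM (on this read-out lower numbers stand for less inhibition of growth and higher numbers for more inhibition of growth at the one concentration tested), compound 3 (`N#C/C(=C\c1ccccc1OS(=O)(=O)c1ccc([N+](=O)[O-])cc1)C(=O)Nc1nnc(Cc2cccc(F)c2)s1`) gives 18% and so lies within the scatter of compound 1 (`COc1ccc(Cc2nnc(NC(=O)/C(C#N)=C/c3ccccc3OS(=O)(=O)c3ccccc3[N+](=O)[O-])s2)cc1`) at 25% but under compound 2 (`N#C/C(=C\c1ccccc1OS(=O)(=O)c1ccccc1[N+](=O)[O-])C(=O)Nc1nnc(Cc2ccc(F)cc2)s1`) at 35% by a margin beyond the scatter. The change to compound 4 (`N#C/C(=C\c1ccccc1OS(=O)(=O)c1ccccc1[N+](=O)[O-])C(=O)Nc1nnc(Cc2cccc(F)c2)s1`) keeps the same atoms and puts 2-nitrophenyl in place of 4-nitrophenyl on a sulfonyl sulfur. Within the data shown here, no measured step covers this change directly. Among the measured compounds shown here, the only measured step, a number 10 percentage points higher from compound 1 to compound 2 (within the scatter), is within the scatter and concerns fluoro in place of methoxy on an aromatic carbon, so it offers only indirect guidance. Compound 1 at 25% and compound 2 at 35% both carry 2-nitrophenyl, as compound 4 will, so a modest rise is expected in this assay and no large jump. The expected step is a number 10 percentage points higher from compound 3 to compound 4 (within the scatter) and it remains a weakly supported expectation. For compound 4 the estimated value is 28% with an expected range from 14% to 42% as the likely span.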

Compound 4, percent growth inhibition at one concentration: 23%
Compound 4: the middle estimate sits 5 percentage points above what was measured; the range from low to high includes it.
By their numbers in this assay, from the lowest: compounds 3, 4, 1 and 2 (each within the scatter of the next, the first and the last beyond it).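

In this assay, 2-nitrophenyl in place of 4-nitrophenyl on a sulfonyl sulfur gives a number 5 percentage points higher from compound 3 to compound 4 (within the scatter), so the place of the nitro group does not separate these two compounds. With 2-nitrophenyl held constant, 3-fluorophenyl in place of 4-fluorophenyl gives a number 12 percentage points lower from compound 2 to compound 4 (beyond the scatter), a modest step, while 3-fluorophenyl in place of 4-methoxyphenyl gives a number 2 percentage points lower from compound 1 to compound 4 (within the scatter). Among these pairs, then, moving the fluoro group registers in this read-out, whereas moving the nitro group does not. No evidence at hand accounts for these steps.

The compounds shown leave open whether moving the nitro group would give the same result with 4-fluorophenyl or 4-methoxyphenyl in the molecule. They also leave open how an amine or a carboxylic acid in place of the nitro group, or chloro in place of fluoro, would affect growth inhibition.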